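A Pyridine Swap Seen on Two Cytotoxicity Scaffolds

This account rests on a few compounds, and the source may have more. Where it says the series, first, only, none or still open, it means among the compounds named here.

Compound 1, `COc1cc(/C=C2\CN(C)C/C(=C\c3cccnc3)C2=O)cc(OC)c1`, gives 18400 nM in an ADME assay on L02 cells (Homo sapiens) for cytotoxicity, read by MTT assay, with a stated time of 24 h; on this read-out higher numbers stand for weaker inhibition and lower numbers for stronger inhibition.
Compound 2, `COc1cc(/C=C2\CN(C)C/C(=C\c3ccncc3)C2=O)cc(OC)c1`, gives 13400 nM in this assay.
Compound 3, `O=C1/C(=C/c2cccnc2)CNC/C1=C\c1ccccc1C(F)(F)F`, gives 11300 nM in this assay.

All three measured values sit within the usual scatter of one another, so none of the three compounds can be set apart from the others on this read-out. Compound 1 and compound 2 differ in a single place: pyridin-4-yl in place of pyridin-3-yl on a double-bonded chain carbon bound to a double-bonded ring carbon. That step gave a 1.4-fold lower number from compound 1 to compound 2 (0.14 log units; within the scatter), a change too small to carry meaning on its own.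

Compound 3 is built on a different core; the difference between the core of compound 3 and the core of compound 1 is not broken down here. Compound 4, `O=C1/C(=C/c2ccncc2)CNC/C1=C\c1ccccc1C(F)(F)F`, stands to compound 3 exactly as compound 2 stands to compound 1: pyridin-4-yl in place of pyridin-3-yl on a double-bonded chain carbon bound to a double-bonded ring carbon. The place of the change is the same in both pairs, so this is the same change made a second time, now on the core of compound 3.

Because the earlier step of a 1.4-fold lower number from compound 1 to compound 2 (0.14 log units; within the scatter) lay within the scatter, the same change on compound 3 is expected to move the number little. Compound 4 is therefore estimated at 9000 nM, with an expected range from 4500 nM to 18000 nM. The step this estimate implies is expected to be a 1.3-fold lower number from compound 3 to compound 4 (0.10 log units; within the scatter).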

Compound 4, half-maximal inhibitory concentration: 13400 nM
The estimate for compound 4 lay 1.5-fold (0.17 log units) below the measured number, and the stated range covers the measured number.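

On the core of compound 3, pyridin-4-yl in place of pyridin-3-yl gave a 1.2-fold higher number from compound 3 to compound 4 (0.07 log units; within the scatter) in this assay. Set beside the same change on the core of compound 1, the two steps cannot be told apart: the same change on two cores in this assay, a 1.4-fold lower number (0.14 log units; within the scatter) from compound 1 to compound 2 and a 1.2-fold higher number (0.07 log units; within the scatter) from compound 3 to compound 4, 1.6-fold (0.21 log units) apart, within the scatter of two such steps

This shows that, on the two cores seen here, the change left the number within the usual scatter of this assay, so the small step seen on the first core was also a small step on the second. It does not show that the change would stay this small on any further core, and since neither step stands clear of the scatter, the pair offers no real test of whether a sizeable effect would carry from one core to another.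

The compounds shown leave open how the number would respond on either core if a group of another kind took this place, such as pyridin-2-yl or a phenyl ring carrying an amine or a carboxylic acid. They also leave open which part of the difference between the core of compound 1 and the core of compound 3 matters, since no pair shown differs in that part alone.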